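Swapping the aryl on the cyclopropane: fluorophenyl to pyridinyl

The compounds below may be only part of what the source reports. "The series", "measured", "known", "first", "only" and "open" are said of these compounds alone.

Of the compounds shown here, three sharing one core have been tested in a functional assay for agonist activity at G protein-coupled receptor 88 (Homo sapiens), read by HTRF and cAMP accumulation; a lower number here means that less compound is needed, a higher number that more compound is needed for the effect. Compound 1 `CC[C@@H](C)[C@H](N)CN(C(=O)[C@@H]1C[C@H]1c1ccccc1)c1ccc(-c2ccccc2)cc1` gives 1.4 nM, compound 2 `CCC(C)CNCCN(C(=O)[C@@H]1C[C@H]1c1ccccc1)c1ccc(-c2ccccc2)cc1` gives 4.7 nM, and compound 3 `CC[C@H](C)[C@H](N)CN(C(=O)[C@@H]1C[C@H]1c1ccccc1F)c1ccc(-c2ccccc2)cc1` gives 650 nM. Compound 3 therefore stands highest of the three, the gap to compound 2 and to compound 1 lying well beyond the scatter. Going by the values given here, the one change between measured neighbours, a 3.4-fold higher number from compound 1 to compound 2 (0.53 log units; beyond the scatter), concerns the amine-bearing chain and is modest.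

Compound 4 `CC[C@H](C)[C@H](N)CN(C(=O)[C@@H]1C[C@H]1c1cccnc1)c1ccc(-c2ccccc2)cc1` differs from compound 3 in a single place: pyridin-3-yl in place of 2-fluorophenyl on a saturated ring carbon. Among the compounds with values here, no measured step touches this part of the molecule, so the only guide is the general observation that compound 3 sits far above the other two. The step is therefore expected to be small and uncertain: compound 4 is estimated at 400 nM, with a range from 60 nM to 3000 nM, which means an expected step of a 1.6-fold lower number from compound 3 to compound 4 (0.21 log units; within the scatter).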

Compound 4, half-maximal effective concentration: 1500 nM
Estimate against measurement, compound 4: 3.8-fold (0.57 log units) below; measured number inside the range.
By their numbers in this assay, from the lowest: compound 1; then compound 2; then compound 3; then compound 4.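

In this assay, the aryl group on the cyclopropane now has a measured step of its own: a 2.3-fold higher number from compound 3 to compound 4 (0.36 log units; beyond the scatter). This shows that the number responds to this position, and that exchanging 2-fluorophenyl, a ring of carbon only, for pyridin-3-yl, which has a ring nitrogen and one hydrogen-bond acceptor, gives no gain here. The step is modest, though it lies beyond the usual scatter, and nothing available explains why the number moves in this direction.

Going by these compounds alone, with only this pair to go on, a single step cannot show a trend for this position. On these data alone, it remains open how a cyclohexyl or thienyl group on the same cyclopropane would compare with 2-fluorophenyl and pyridin-3-yl.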